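Bromo to Nitrooxy on an Acetamide Side Chain

The source may hold more compounds than are shown below. What is called first, only, known or untested is meant among the compounds shown, and "the series" means these compounds.

Measured compounds:
compound 1, `Nc1ccc(C(=O)/C=C/c2ccco2)cc1`, 33%
compound 2, `COc1ccc(/C=C/C(=O)c2ccc(NC(=O)CBr)cc2)cc1`, 41%

In a functional assay on the whole organism (strain albino) for inhibition, with Rattus norvegicus as the target, read by paw edema, with stated times of 30 min and 4 h, at a dose of 100 mg/kg by the oral route (a higher number here means more inhibition at the dose given (going by the name of the read-out), a lower number less inhibition), compound 1 gives 33%, and compound 2 gives 41%. The two structures differ in more than one place, so nothing is made of the gap between them beyond what the two values show: they lie within the scatter of each other, and neither can be set above the other on this evidence. Compound 2 is therefore one of two compounds whose values cannot be told apart.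

Compound 3, `COc1ccc(/C=C/C(=O)c2ccc(NC(=O)CO[N+](=O)[O-])cc2)cc1`, has not yet been measured in this assay. It differs from compound 2 in a single place: nitrooxy in place of bromo on a saturated chain carbon bound to a carbonyl carbon. Going by the values given here, no measured pair in this set shows a change of this kind, so no step size can be read from the data. Compound 3 is expected to give a value close to that of compound 2, with a step of a number 1 percentage points higher from compound 2 to compound 3 (within the scatter) that is estimated to fall within the scatter in either direction. On that basis the estimate for compound 3 is 42%, with a range from 25% to 60%.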

Compound 3, a percentage reported as inhibition, in the whole organism at one dose (the size of the read-out at that dose, not a potency): 51%
Compound 3: middle estimate off by 9 percentage points, on the low side; measured number inside the range.
By their numbers in this assay, from the lowest: compounds 1, 2 and 3 (each within the scatter of the next, the first and the last beyond it).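

Nitrooxy in place of bromo on a saturated chain carbon bound to a carbonyl carbon gives a number 10 percentage points higher from compound 2 to compound 3 (within the scatter) in this assay and is the first step that can be read at this position. The change replaces a single bromine with a group of four heavy atoms and three hydrogen-bond acceptors, yet the paw edema inhibition at the dose given stays within the scatter, so this one pair shows that the position accepts the larger nitrooxy group without a loss beyond the scatter. Nothing shown gives a reason for the two values standing where they do.

A hydroxy group or an amine on that same chain carbon, or a longer chain carrying the nitrooxy, would show whether the value depends on nitrooxy itself or on the acetamide side chain as a whole. On these data alone, with one dose and one step, it also stays open whether the exchange would give a step of similar size on a different core, such as the core of compound 1, or whether a gap beyond the scatter could appear at all.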